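The source may hold more compounds than are shown below. What is called first, only, known or untested is meant among the compounds shown, and "the series" means these compounds.

Measured compounds:
Compound 1 `CCOC(=O)C1=C(C)NC(=O)NC1c1cn(-c2ccccc2)nc1-c1ccccc1` gives 60800 nM in a functional assay on MCF7 cells (Homo sapiens) for inhibition, read by sulforhodamine B assay, with a stated time of 24 h; on this read-out higher numbers stand for weaker inhibition of growth and lower numbers for stronger inhibition of growth.
Compound 2 `CCOC(=O)C1=C(C)NC(=S)NC1c1cn(-c2ccccc2)nc1-c1ccccc1` gives 42000 nM in this assay.
Compound 3 `CCOC(=O)C1=C(C)NC(=S)NC1c1cn(-c2ccccc2)nc1-c1ccc(Cl)cc1` gives 33200 nM in this assay.

Compound 3 shows the lowest of the three numbers, yet its gaps to compound 2 and to compound 1 both lie within the usual scatter, so the three stand level. For the measured compounds named here, the only step between close neighbours, a 1.3-fold lower number from compound 2 to compound 3 (0.10 log units; within the scatter), is itself within the scatter. Compound 4 `COc1ccc(NC(=O)C2=C(C)NC(=S)NC2c2cn(-c3ccccc3)nc2-c2ccc(Cl)cc2)cc1` differs from compound 3 by (4-methoxyphenyl)amino in place of ethoxy on a carbonyl carbon. Going by the values given here, no measured step concerns this kind of change; the one step on record involves a chloro group on an aromatic carbon and says nothing about it. For compound 4 the expectation is therefore a number in the same region, a 1.3-fold lower number from compound 3 to compound 4 (0.12 log units; within the scatter), with wide uncertainty: an estimated 25000 nM, between 8000 nM and 80000 nM.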

Compound 4, concentration for 50% growth inhibition: 70000 nM
Compound 4: the middle estimate sits 2.8-fold (0.45 log units) below what was measured; the measured number falls inside the stated range.
By their numbers in this assay, from the lowest: compounds 3, 2, 1 and 4 (each within the scatter of the next, the first and the last beyond it).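

For the compounds shown here, putting (4-methoxyphenyl)amino in place of ethoxy on the carbonyl carbon produces the only step here beyond the scatter: in this assay, there is a 2.1-fold higher number from compound 3 to compound 4 (0.32 log units; beyond the scatter). This modest step shows that growth inhibition responds to a change at this carbonyl carbon, and that this exchange weakens it rather than strengthens it. Nothing available explains the shift.

From the compounds shown here alone, whether the aromatic ring, its methoxy group or the amide hydrogen matters most remains open. So does the effect of a carboxylic acid or a simple methylamino group at this carbon.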